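The source may report more compounds than this note shows. Statements on the series, on what has been measured and on what is new or still open speak of the compounds shown alone.

Measured in a functional assay on SK-OV-3 cells (Homo sapiens) for cytotoxicity; on this read-out lower numbers stand for stronger inhibition and higher numbers for weaker inhibition:
compound 1 `C=C/C=C\[C@H](C)[C@H](OC(N)=O)[C@@H](C)[C@H](O)[C@@H](C)C/C(C)=C\[C@H](C)[C@@H](O)[C@@H](C)/C=C\CCc1sccc1C`: 370 nM
compound 2 `C=C/C=C\[C@H](C)[C@H](OC(N)=O)[C@@H](C)[C@H](O)[C@@H](C)C/C(C)=C\[C@H](C)[C@@H](O)[C@@H](C)/C=C\CCc1ccsc1`: 440 nM

Among the compounds with values here, compound 2, at 440 nM, cannot be told apart from compound 1, at 370 nM: a 1.2-fold higher number from compound 1 to compound 2 (0.08 log units; within the scatter) is the only measured step. Compound 3 `C=C/C=C\[C@H](C)[C@H](OC(N)=O)[C@@H](C)[C@H](O)[C@@H](C)C/C(C)=C\[C@H](C)[C@@H](O)[C@@H](C)/C=C\CCc1cccc(O)c1` has not yet been measured. It carries 3-hydroxyphenyl in place of thiophen-3-yl on a saturated chain carbon, two bonds along the chain from a double-bonded chain carbon. Within the data shown here, the one measured step at this place exchanges one thiophene-based group for another, so it bears only indirectly on the change. Among the measured compounds shown here, no measured compound shows what a six-membered aromatic ring or a hydroxyl group does here. In this assay, no clear direction can therefore be expected, and the range stays wide. The expected change is a 1.1-fold lower number from compound 2 to compound 3 (0.04 log units; within the scatter). For compound 3 the estimated value is 400 nM, with an expected range of 100 nM to 1500 nM.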

Compound 3, half-maximal inhibitory concentration: 40 nM
For compound 3 the middle estimate is 10-fold (1.00 log units) above the measured one, outside the stated range (below it).
By their numbers in this assay, from the lowest: compound 3; then compounds 1 and 2 (each within the scatter of the next).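

In this assay, a saturated chain carbon two bonds along the chain from a double-bonded chain carbon proves sensitive to the group it carries: 3-hydroxyphenyl in place of thiophen-3-yl gives an 11-fold lower number from compound 2 to compound 3 (1.04 log units; beyond the scatter) and 3-hydroxyphenyl in place of 3-methylthiophen-2-yl gives a 9.3-fold lower number from compound 1 to compound 3 (0.97 log units; beyond the scatter) at the same place. Within the data shown here, the two thiophene-based groups lie within the scatter of each other, so the earlier compounds gave no sign of this sensitivity. Nothing at hand bears on the reason for the lower number.

The change replaces the thiophene ring with a six-membered aromatic ring of carbon only and adds a hydroxyl group in one step, so the compounds shown do not separate the two. Also open, as far as these compounds go, is how a plain phenyl group would compare, or a phenyl group carrying a methoxy group or an amine in place of the hydroxyl.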